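The source may hold more compounds than are shown below. What is called first, only, known or untested is meant among the compounds shown, and "the series" means these compounds.

Measured so far in a functional assay on M14 cells (Homo sapiens) for cytotoxicity; a lower number here means a stronger inhibitor of growth, a higher number a weaker inhibitor of growth:
- compound 1 `CSc1ccc(C2=C(c3ccc(F)c(F)c3)C(=O)N3CCCC3C2)cc1`: 300 nM
- compound 2 `CSc1ccc(C2=C(c3ccc(C)c(C)c3)C(=O)N3CCCC3C2)cc1`: 800 nM
- compound 3 `CSc1ccc(C2=C(c3ccc(O)cc3)C(=O)N3CCCC3C2)cc1`: > 100000 nM (a limit)

Compound 3 has no number, only a limit, > 100000 nM. As far as these compounds go, on the values shown it is the weakest of the three, and the true size of any step from it remains open.

The next compound is compound 4 `CSc1ccc(C2=C(c3ccc(C)cc3)C(=O)N3CCCC3C2)cc1`. The change is methyl in place of hydroxy on an aromatic carbon, para to a large group, so that 4-hydroxyphenyl becomes 4-methylphenyl.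

Within the data shown here, two measured steps bear directly on this position, both large and both ending at the hydroxy compound: an at least 330-fold higher number from compound 1 to compound 3 (2.52 log units; beyond the scatter), and an at least 120-fold higher number from compound 2 to compound 3 (2.09 log units; beyond the scatter). Exchanging the two groups without hydroxy matters far less, with a 2.7-fold higher number from compound 1 to compound 2 (0.43 log units; beyond the scatter), a modest step. The 4-methylphenyl group resembles by name the 3,4-dimethylphenyl group of compound 2, which gives 800 nM.

Removing the hydroxy is therefore expected to give a large step in this assay towards a lower number, similar in size to the two steps above. The expected step is an at least 100-fold lower number from compound 3 to compound 4 (2.00 log units; beyond the scatter). For compound 4 the estimated value is 1000 nM, with an expected range of 250 nM to 5000 nM.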

Compound 4, concentration for 50% growth inhibition: 6000 nM
Beside the measured number, compound 4's estimate is 6.0-fold (0.78 log units) below it; the whole stated range lies below it.
By their numbers in this assay, from the lowest: compound 1; then compound 2; then compound 4. At a limit, above all of these: compound 3.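

In this assay the exchange of hydroxy for methyl on this aromatic carbon, para to a large group, brings a 4-substituted phenyl compound into a measurable range (an at least 16-fold lower number from compound 3 to compound 4 (1.22 log units; beyond the scatter)), so the earlier drop at compound 3 can be set against a single atom exchange rather than against a change of substitution count as well. The size of that step stays unfixed, as it starts from the limit of compound 3: the limit of > 100000 nM in this assay, at which 1 of the 4 values shown sits.

The methyl alone does not reach the level of the disubstituted compounds, as the loss of the second methyl (a 7.5-fold higher number from compound 2 to compound 4 (0.88 log units; beyond the scatter)) and the comparison with the 3,4-difluorophenyl group (a 20-fold higher number from compound 1 to compound 4 (1.30 log units; beyond the scatter)) both show, so 4-methylphenyl and 3,4-dimethylphenyl are not interchangeable in this series.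

Still open, as far as these compounds go, is how a methoxy, a chlorine or an amine on the same aromatic carbon would sit relative to compound 4 and compound 3. Also open, from the compounds shown here alone, is whether a single fluorine there would hold closer to compound 1 than the methyl holds to compound 2.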